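The source may report more compounds than this note shows. Statements on the series, on what has been measured and on what is new or still open speak of the compounds shown alone.

Working notes on the series built on the shared core of compound 1 `CCCCCCN1CCC(C(=O)Nc2cc(Cl)c(N)cc2OC)CC1`. In a functional assay on the whole organism for antagonist activity, with Mus musculus as the target (a lower number here means that less compound is needed, a higher number that more compound is needed for the effect), compound 1 gives > 10 mg/kg and this is a limit of the assay, not a number. Compound 2 `COc1cc(N)c(Cl)cc1NC(=O)C1CCN(Cc2ccccc2Cl)CC1` is the next member. In this assay compound 2 gives > 4 mg/kg, again a limit rather than a measured value. Compound 3 `CCCCN1CCC(C(=O)Nc2cc(Cl)c(N)cc2OC)CC1` completes the measured set. In this assay compound 3 gives > 10 mg/kg, once more only a limit. Where compound 3 stands is therefore known only as a bound, and the other two values shown are bounds as well. The measured steps a step that the two limits leave unreadable from compound 1 to compound 2, a step that the two limits leave unreadable from compound 1 to compound 3 and a step that the two limits leave unreadable from compound 2 to compound 3 are all of unreadable size because the limit of > 10 mg/kg in this assay, at which 2 of the 3 values shown sit, and the limit of > 4 mg/kg in this assay, at which 1 of the 3 values shown sits, are all the three measurements amount to.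

Compound 4 `CCOc1ccc(CN2CCC(C(=O)Nc3cc(Cl)c(N)cc3OC)CC2)cc1` is not yet measured; its change from compound 3 is 4-ethoxyphenyl in place of propyl on a saturated chain carbon bound to an amine nitrogen in a ring. The step bearing on it is a step that the two limits leave unreadable from compound 2 to compound 3, which placed a 2-chlorophenyl on the same carbon and stayed unreadable. With no readable step in this assay, the expected step of an at least 1.2-fold lower number from compound 3 to compound 4 (0.09 log units; that floor lies within the scatter) for compound 4 is anchored only on the bounds. Compound 4 is expected near 8 mg/kg in this assay, within a range from 1.5 mg/kg to 30 mg/kg, with a fair chance that only a limit is reported.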

Compound 4, dose for half-maximal effect: 6.3 mg/kg
Estimate against measurement, compound 4: 1.3-fold (0.10 log units) above, within the range that was stated.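

In this assay compound 4 is the only compound shown with a measured value, 6.3 mg/kg, so 4-ethoxyphenyl on a saturated chain carbon bound to an amine nitrogen in a ring gives a result that is a number rather than a limit. Placing 4-ethoxyphenyl on this carbon gives an at least 1.5-fold lower number from compound 3 to compound 4 (0.20 log units; that floor lies within the scatter) in place of propyl and an at least 1.5-fold lower number from compound 1 to compound 4 (0.20 log units; that floor lies within the scatter) in place of pentyl, so the change from either alkyl chain is known only as a floor, and neither floor establishes a change beyond the scatter. The step from compound 2 to compound 4, like the steps among compounds 1, 2 and 3, cannot be read, because those comparisons rest on limits: the limit of > 4 mg/kg in this assay, at which 1 of the 4 values shown sits.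

The compounds shown leave open how large the change from the alkyl chains really is and whether it follows from the aromatic ring itself or from the ethoxy group on it. An unsubstituted phenyl or a pyridyl ring on the same carbon would bear on that question, and compound 2, with 2-chlorophenyl there, does not settle it.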